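The compounds below may be only part of what the source reports. "The series", "measured", "known", "first", "only" and "open" are said of these compounds alone.

Compound 1 `COc1cc(OC)c(/C=C/S(=O)(=O)Cc2ccc(OC)c(N)c2)c(OC)c1` and compound 2 `COc1ccc(CS(=O)(=O)/C=C/c2cc(OC)c(OC)c(OC)c2)cc1N` are built from the same atoms joined in different arrangements; how the two cores differ is not broken down here. In a functional assay on K562 cells (Homo sapiens) for cytotoxicity, read by trypan blue exclusion, with a stated time of 96 h (on this read-out higher numbers stand for weaker inhibition and lower numbers for stronger inhibition), compound 1 gives 2.5 nM. In this assay compound 2 gives 250 nM, the highest number among the three measured compounds, and its steps to the other two are both beyond the scatter of repeated measurement.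

Compound 3 `COC(=O)CNc1cc(CS(=O)(=O)/C=C/c2c(OC)cc(OC)cc2OC)ccc1OC` is compound 1 carrying ((methoxycarbonyl)methyl in place of hydrogen on a nitrogen on an aromatic ring). In this assay compound 3 gives 100 nM. For the measured compounds named here, the step of a 40-fold higher number from compound 1 to compound 3 (1.60 log units; beyond the scatter) is a large one, well beyond the usual scatter, and it is the only measured example of this change.

Compound 4 `COC(=O)CNc1cc(CS(=O)(=O)/C=C/c2cc(OC)c(OC)c(OC)c2)ccc1OC` has not yet been measured. Going by the values given here, it arises from compound 2 through ((methoxycarbonyl)methyl in place of hydrogen on a nitrogen on an aromatic ring), which is the same change as the one leading from compound 1 to compound 3, now made on the core of compound 2. Among the compounds with values here, for compound 4 the expected step is a 24-fold higher number from compound 2 to compound 4 (1.38 log units; beyond the scatter), because a 40-fold higher number from compound 1 to compound 3 (1.60 log units; beyond the scatter) is the one measured instance of this change and nothing among the measured compounds points the other way. Since the core differs and the change has been seen only once, the expectation is held loosely. Compound 4 is therefore estimated at 6000 nM in this assay. The expected range for compound 4 runs from 1200 nM to 30000 nM.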

Compound 4, half-maximal inhibitory concentration: 30000 nM
The estimate for compound 4 lay 5.0-fold (0.70 log units) below the measured number; the measured number falls inside the stated range.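

In this assay, putting (methoxycarbonyl)methyl in place of hydrogen on a nitrogen on an aromatic ring weakens inhibition on a second core as well, giving a 120-fold higher number from compound 2 to compound 4 (2.08 log units; beyond the scatter). The direction of the change therefore carries over from one core to the other, but its size does not carry over exactly: the same change on two cores in this assay, a 40-fold higher number (1.60 log units; beyond the scatter) from compound 1 to compound 3 and a 120-fold higher number (2.08 log units; beyond the scatter) from compound 2 to compound 4, 3.0-fold (0.48 log units) apart, beyond the scatter of two such steps. For the compounds shown here, these are only two examples, so they do not make a rule for other cores, and the numbers alone do not explain why the loss differs between the two cores.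

The compounds shown leave open whether the loss belongs to this particular group or would follow any substituent on that nitrogen, such as a simple methyl, an acetyl or a longer chain ending in the same ester. They also leave open what the free carboxylic acid in place of the methyl ester would do on either core, and whether it would show the same gap between the two cores.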